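Notes on the aryl enone series: compound 3

The compounds below may be only part of what the source reports. "The series", "measured", "known", "first", "only" and "open" are said of these compounds alone.

Of the compounds shown here, two of the shared core have been measured in a functional assay on SF-268 cells (Homo sapiens) for cytotoxicity, read by sulforhodamine B assay, with a stated time of 48 h, tested at 100 uM; on this read-out higher numbers stand for a weaker effect at the one concentration tested and lower numbers for a stronger effect. Compound 1 `COc1cc(-c2cc(/C=C/C(=O)c3ccc(N)cc3)[nH]n2)cc(OC)c1OC` gives -80%. Compound 2 `COc1ccc(C(=O)/C=C/c2cc(-c3cc(OC)c(OC)c(OC)c3)n[nH]2)cc1` gives -37%, the highest of the two numbers and thus the weaker effect at the single concentration. Among the measured compounds shown here, the only step in hand is a number 43 percentage points higher from compound 1 to compound 2 (beyond the scatter), a methoxy in place of an amino on the ring attached to the carbonyl carbon. Compound 3 `COc1cc(-c2cc(/C=C/C(=O)c3ccc(F)c(F)c3)[nH]n2)cc(OC)c1OC` differs from compound 2 by 3,4-difluorophenyl in place of 4-methoxyphenyl on a carbonyl carbon. For the measured compounds named here, no measured step exchanges that whole ring; the step from compound 1 to compound 2 touches the same ring but only one group on it, so it bears on the present change only loosely, showing that this ring moves the read-out in this assay. The direction is therefore uncertain, and a wide range is expected. For compound 3 in this assay a value of -50% is expected, with a range from -85% to -10%. The expected step of a number 13 percentage points lower from compound 2 to compound 3 (beyond the scatter) is toward a somewhat stronger effect, though it may well stay within the scatter.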

Compound 3, a percentage reported as activity, at one concentration (the size of the read-out at that concentration, not a potency): 1%
For compound 3 the middle estimate is 51 percentage points below the measured one, outside the stated range (above it).
By their numbers in this assay, from the lowest: compound 1; then compound 2; then compound 3.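

In this assay, exchanging 4-methoxyphenyl for 3,4-difluorophenyl on a carbonyl carbon gives a number 38 percentage points higher from compound 2 to compound 3 (beyond the scatter), and exchanging 4-aminophenyl for the same ring gives a number 81 percentage points higher from compound 1 to compound 3 (beyond the scatter). Among the compounds shown here, the earlier step showed only that one group on this ring moves the read-out; now the whole ring proves decisive, and compound 3 at 1% shows that the negative numbers of compound 1 and compound 2 do not hold for every ring at this place. No measurement at hand accounts for this difference.

The compounds shown leave open whether the two fluorines act together or whether one alone would give the same read-out. Going by these compounds, how a dimethylamino group or a carboxylic acid on this ring would read also remains open.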